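Thiophene-series notes: bromo replacing 4-methylphenyl, compound 4

A few compounds are considered here, and "the series" means these few. Any claim that something is new, unique, unknown or untested is made for them only; others in the source may bear on it.

Measured compounds:
compound 1 `CC(C)(C)Cc1csc(N)c1C(=O)c1ccc(Cl)cc1`, 5%
compound 2 `Cc1c(Br)sc(N)c1C(=O)c1ccc(Cl)cc1`, 1%
compound 3 `Cc1ccc(-c2sc(N)c(C(=O)c3ccc(Cl)cc3)c2CC(C)(C)C)cc1`, 1%

All three numbers come from an assay on CHO cells for displacement of a labelled ligand from adenosine receptor A3 (Homo sapiens), read by scintillation counting, tested at 10 uM; on this read-out higher numbers stand for more inhibition at the one concentration tested (going by the name of the read-out) and lower numbers for less inhibition. Compound 3 stands level with compound 2 at the digits printed, the two together being the lowest of the three numbers; its furthest neighbour is compound 1, whose number is higher by an amount within the scatter. Among the compounds with values here, the one measured step that reaches compound 3, a number 4 percentage points lower from compound 1 to compound 3 (within the scatter), is itself within the scatter.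

Compound 4 `CC(C)(C)Cc1c(Br)sc(N)c1C(=O)c1ccc(Cl)cc1` differs from compound 3 in one place: bromo in place of 4-methylphenyl on an aromatic carbon. The step from compound 1 to compound 3 bears on the same aromatic carbon and produced no shift beyond the scatter. Compound 2 also carries bromo on its ring, but it differs from compound 4 in a second place as well, so only its own value, together with that of compound 3, can be read. With every number of the series lying in the same low band, no step beyond the scatter is expected for compound 4 in this assay; the expected step is a number 2 percentage points higher from compound 3 to compound 4 (within the scatter). The estimate for compound 4 is therefore 3%, with a range from -6% to 12%.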

Compound 4, a percentage reported as inhibition, at one concentration (the size of the read-out at that concentration, not a potency): 1%
The estimate for compound 4 lay 2 percentage points above the measured number; measured number inside the range.
By their numbers in this assay, from the lowest: compounds 2, 3, 4 and 1 (each within the scatter of the next).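

In this assay, within the data shown here, the aromatic carbon next to the ring sulfur has now been read with hydrogen, 4-methylphenyl and bromo, and no pair of these separates: bromo in place of 4-methylphenyl gives (no change at the digits printed from compound 3 to compound 4 (within the scatter)) and bromo in place of hydrogen gives (a number 4 percentage points lower from compound 1 to compound 4 (within the scatter)). With bromo on this carbon, tert-butyl in place of hydrogen on the saturated chain carbon also leaves the read-out unmoved (no change at the digits printed from compound 2 to compound 4 (within the scatter)), so a change at this second place does not separate the compounds either. Nothing available here accounts for this lack of response.

Going by these compounds, whether an aminomethyl group or a carboxylic acid on this aromatic carbon would give a step beyond the scatter remains open. So does the effect of a longer chain in place of the neopentyl group.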